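This account rests on a few compounds, and the source may have more. Where it says the series, first, only, none or still open, it means among the compounds named here.

Working notes on the series. Among the measured compounds shown here, compound 1 `Cc1ccc(N2CCN(C(=S)SCc3ccc4nc(N)nc(N)c4c3)CC2)cc1` is the one measured member: in a functional assay on HeLa cells (Homo sapiens) for antiproliferative activity, read by MTT assay, with a stated time of 72 h (a lower number here means a stronger inhibitor, a higher number a weaker inhibitor), compound 1 gives 2130 nM. Compound 2 `Cc1ccccc1N1CCN(C(=S)SCc2ccc3nc(N)nc(N)c3c2)CC1` carries a 2-methylphenyl in place of the 4-methylphenyl of compound 1 on the same amine nitrogen in a ring, but for compound 2 "not determined" (no result reported) is recorded, so compound 2 stands on no number at all in this assay. Compound 3 `Nc1nc(N)c2cc(CSC(=S)N3CCN(c4ccc([N+](=O)[O-])cc4)CC3)ccc2n1` is the next member to be measured. Against compound 2 the change is 4-nitrophenyl in place of 2-methylphenyl on an amine nitrogen in a ring. For the measured compounds named here, with nothing measured for compound 2, no step from compound 2 to compound 3 can be sized; the only anchor is compound 1, and an aryl swap of this kind is expected to move this assay by no more than the scatter, in no set direction. On that basis compound 3 is estimated at 2000 nM, with a range of 600 nM to 7000 nM.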

Compound 3, half-maximal inhibitory concentration: 1660 nM
The estimate for compound 3 lay 1.2-fold (0.08 log units) above the measured number, within the range that was stated.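

In this assay, among the compounds shown here, nitro in place of methyl on an aromatic carbon gives a 1.3-fold lower number from compound 1 to compound 3 (0.11 log units; within the scatter), the first step that can be read at this position, and it shows that this exchange on the phenyl ring leaves the number within the scatter. Across this pair, therefore, the 4-methylphenyl and 4-nitrophenyl groups on the amine nitrogen in a ring cannot be told apart in this assay, while the steps that involve compound 2 cannot be read. No measurement bears on why the exchange leaves the number within the scatter.

One pair cannot show whether this holds for other groups on the phenyl ring, such as an amine or a carboxylic acid. It also leaves open whether the piperazine-bound aryl group could be replaced by a benzyl group without moving the number beyond the scatter.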